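Bicyclic amide variation on a sulfonyl benzylamide scaffold

The source may hold more compounds than are shown below. What is called first, only, known or untested is meant among the compounds shown, and "the series" means these compounds.

Measured compounds:
compound 1 `O=C(NCc1ccc(S(=O)(=O)c2ccccc2)cc1)c1ccc2ncncc2c1`: 1900 nM
compound 2 `O=C(NCc1ccc(S(=O)(=O)c2ccccc2)cc1)c1nc2cnccc2[nH]1`: 7100 nM

In an assay for inhibition of Nicotinamide phosphoribosyltransferase (Homo sapiens), read by mass spectrometry, with stated times of 15 min and 30 min (on this read-out higher numbers stand for weaker inhibition and lower numbers for stronger inhibition), compound 2 gives 7100 nM, the higher of the two numbers; compound 1 gives 1900 nM, a gap beyond the usual scatter. Compound 3 `O=C(NCc1ccc(S(=O)(=O)c2ccccc2)cc1)c1cc2ccncc2s1` differs from compound 2 by a group of 9 heavy atoms (7 carbon, 1 nitrogen, 1 sulfur; one five-membered aromatic ring with 1 hetero atom, one six-membered aromatic ring with 1 hetero atom) in place of a group of 9 heavy atoms (6 carbon, 3 nitrogen; one five-membered aromatic ring with 2 hetero atoms, one six-membered aromatic ring with 1 hetero atom), on a carbonyl carbon. Among the measured compounds shown here, no measured pair covers this exchange, so the step is uncertain; a moderate move toward a lower number is expected, possibly beyond the scatter, since compound 1 shows that another bicyclic amide without the imidazole donor gives 1900 nM. For compound 3 the estimate is 3000 nM, within 800 nM to 12000 nM, an expected step of a 2.4-fold lower number from compound 2 to compound 3 (0.37 log units; beyond the scatter).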

Compound 3, half-maximal inhibitory concentration: 7 nM
Estimate against measurement, compound 3: 430-fold (2.63 log units) above; the whole stated range lies above it.
By their numbers in this assay, from the lowest: compound 3; then compound 1; then compound 2.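

At this carbonyl carbon, the choice of fused aromatic group can shift the number sharply: in this assay the exchange gives a 1000-fold lower number from compound 2 to compound 3 (3.01 log units; beyond the scatter). The two groups match in heavy-atom count and hydrogen-bond acceptors, differing in ring hetero atoms and in the hydrogen-bond donor, which the entering group lacks. Nothing available explains the size of this step.

Which of these differences carries the step remains open. So does whether a group with oxygen in place of the sulfur would keep a number close to that of compound 3.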